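The source may hold more compounds than are shown below. What is called first, only, known or untested is meant among the compounds shown, and "the series" means these compounds.

In a functional assay, with a stated time of 150 min (on this read-out higher numbers stand for weaker inhibition and lower numbers for stronger inhibition), compound 1 `CCOC(=O)c1cnn(-c2nc(-c3ccc(Cl)cc3)c(C#N)c(=O)n2C)c1N` gives 87 ug/mL, and compound 2 `CSc1nc(-c2ccc(N(C)C)cc2)c(C#N)c(=O)n1C` gives 93 ug/mL. These two numbers lie within the usual scatter of each other, so compound 1 cannot be set apart from compound 2 in this assay. Compound 3 `CCOC(=O)c1cnn(-c2nc(-c3ccccc3O)c(C#N)c(=O)n2C)c1N` has not yet been measured; it differs from compound 1 by 2-hydroxyphenyl in place of 4-chlorophenyl on an aromatic carbon. Among the compounds with values here, no step between measured compounds bears on this change, so the two numbers so far give no guide to its direction, and a shift no larger than the scatter is expected. Compound 3 is estimated at 80 ug/mL, with a range from 40 ug/mL to 160 ug/mL. The step expected is a 1.1-fold lower number from compound 1 to compound 3 (0.04 log units; within the scatter).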

Compound 3, half-maximal inhibitory concentration: 64 ug/mL
The estimate for compound 3 lay 1.3-fold (0.10 log units) above the measured number, and the stated range covers the measured number.
By their numbers in this assay, from the lowest: compounds 3, 1 and 2 (each within the scatter of the next).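

In this assay, 2-hydroxyphenyl in place of 4-chlorophenyl on this aromatic carbon gives a 1.4-fold lower number from compound 1 to compound 3 (0.13 log units; within the scatter) and so does not separate the two compounds, even though a hydrogen-bond donor enters and the chlorine leaves. This position therefore accepts two differently substituted phenyl groups with no step beyond the scatter. Nothing available explains this result. The compounds shown leave open whether a phenyl group bearing an amine or a carboxylic acid, or a cyclohexyl group, would move the number beyond the scatter.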